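This account rests on a few compounds, and the source may have more. Where it says the series, first, only, none or still open, it means among the compounds named here.

Measured so far in a functional assay on HCT-15 cells (Homo sapiens) for antiproliferative activity, read by sulforhodamine B assay, with a stated time of 48 h, tested at 50 uM; on this read-out lower numbers stand for less inhibition and higher numbers for more inhibition at the one concentration tested (going by the name of the read-out):
Compound 1 `CC1=CC[C@H](C(C)C)c2cc(C)c(OC(=O)c3ccc(Cl)cc3)cc21` gives 47.4%.
Compound 2 `Cc1cc2c(C(C)C)ccc(C)c2cc1OC(=O)c1ccc(C(F)(F)F)cc1` gives 55.6%.
Compound 3 `COc1cccc(C(=O)Oc2cc3c(C)ccc(C(C)C)c3cc2C)c1` gives 35.2%.

Compound 1 stands second highest of these three numbers. Its nearest neighbour is compound 2, whose number is higher, but the gap lies within the scatter of repeated measurements, so no order between compound 1 and compound 2 can be read from this pair. Compound 3 sits furthest off, with a number lower than that of compound 1 by more than the scatter. Among the compounds with values here, compound 3 and compound 1 differ in more than one place, and no single step connects them.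

Compound 4 `CC1=CC[C@H](C(C)C)c2cc(C)c(OC(=O)c3ccccc3)cc21` has not been measured. It differs from compound 1 in one place: hydrogen in place of chloro on an aromatic carbon. Within the data shown here, no pair among the measured compounds walks this same step, so its size can only be estimated. The change removes one heavy atom, a chlorine, and brings in no ring, no donor and no acceptor.

In this assay a modest step downward from compound 1 to compound 4 is expected, a number 7.4 percentage points lower from compound 1 to compound 4 (within the scatter), a step close to the edge of the scatter rather than clearly beyond it. The estimate for compound 4 is 40%, with a range from 25% to 55%.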

Compound 4, a percentage reported as inhibition, at one concentration (the size of the read-out at that concentration, not a potency): 49.5%
The estimate for compound 4 lay 9.5 percentage points below the measured number; measured number inside the range.
By their numbers in this assay, from the lowest: compound 3; then compounds 1, 4 and 2 (each within the scatter of the next).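

In this assay, within the data shown here, the change from 4-chlorophenyl to phenyl, on an aromatic carbon para to a large group, is the first single-place step: a number 2.1 percentage points higher from compound 1 to compound 4 (within the scatter). No order can be read between this pair, so on the core of compound 1 the chloro at this carbon is not required for the inhibition seen at the one concentration tested, and the ring without it stays level with the chloro compound within the scatter. No supporting data bear on the reason for this result.

On these data alone, whether another group at this carbon, such as an amine, a carboxylic acid or a longer chain, would give a step beyond the scatter remains open, as the chloro-to-hydrogen step is the only one available here. Also open, as far as these compounds go, is whether the same step would read alike on the core of compound 2, and since each number is the size of the read-out at one concentration, the pair gives no comparison of potency.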